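A few compounds are considered here, and "the series" means these few. Any claim that something is new, unique, unknown or untested is made for them only; others in the source may bear on it.

Compound 3 `Oc1ccc(-c2cc(-c3cccc(OC(F)(F)F)c3)cc(-c3ccccc3O)n2)cc1` is one of three close relatives that have been tested in a functional assay on T47D cells (Homo sapiens) for inhibition; on this read-out higher numbers stand for weaker inhibition and lower numbers for stronger inhibition. In this assay compound 3 gives > 50000 nM, which is a limit of the assay and not a number. Compound 1 `Oc1ccc(-c2cc(-c3cccc(F)c3)cc(-c3ccccc3O)n2)cc1` gives > 50000 nM in this assay, again a limit. Compound 2 `Oc1ccc(-c2cc(-c3cccc(F)c3)cc(-c3ccc(O)cc3)n2)cc1` gives > 50000 nM in this assay, also a limit. All three values sit at the same limit (the limit of > 50000 nM in this assay, at which 3 of the 3 values shown sit), so compound 3 cannot be placed above or below its two neighbours on the numbers shown.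

Compound 4 `Oc1ccc(-c2cc(-c3cccc(OC(F)(F)F)c3)cc(-c3ccc(O)cc3)n2)cc1` is not yet measured. It differs from compound 3 in one place: 4-hydroxyphenyl in place of 2-hydroxyphenyl on an aromatic carbon. The same exchange has been made once already, and there the step that the two limits leave unreadable from compound 1 to compound 2. The other step that the two limits leave unreadable from compound 1 to compound 3 is equally unreadable. Among the compounds with values here, no measured step therefore gives a readable size or direction for this change. The step expected in this assay is a step that the limit leaves unreadable from compound 3 to compound 4, meaning no change that could be read at the limit. Compound 4 is estimated at 100000 nM, within 40000 nM to 400000 nM, and is expected to be reported as a limit again.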

Compound 4, half-maximal inhibitory concentration: > 50000 nM
Compound 4 gave a limit, no number; the forecaster's own chance of this, stated with the estimate: 90%; the middle value lies beyond the limit too.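

Neither new step, from compound 3 to compound 4 or from compound 2 to compound 4, can be read, because both ends of each step are limits and not numbers: the limit of > 50000 nM in this assay, at which 4 of the 4 values shown sit.

The compounds shown leave open whether 2-hydroxyphenyl or 4-hydroxyphenyl, or fluoro or trifluoromethoxy, makes any difference in this assay.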